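Series notes: styryl replacing chlorophenyl at the saturated ring carbon

The source may hold more compounds than are shown below. What is called first, only, known or untested is meant among the compounds shown, and "the series" means these compounds.

Measured so far:
- compound 1, `Cc1cc(O)c(C2=NN(c3ccc(S(N)(=O)=O)cc3)C(c3ccccc3O)C2)cc1Cl`: 26000 nM
- compound 2, `Cc1cc(O)c(C2=NN(c3ccc(S(N)(=O)=O)cc3)C(c3ccccc3Cl)C2)cc1Cl`: 22000 nM

Both numbers come from a functional assay on NCI-H322M cells (Homo sapiens) for antiproliferative activity, with a stated time of 48 h; on this read-out lower numbers stand for higher toxicity in this test and higher numbers for lower toxicity in this test. Going by the values given here, the single step between measured compounds, a 1.2-fold lower number from compound 1 to compound 2 (0.07 log units; within the scatter), is chloro in place of hydroxy on an aromatic carbon and stays within the scatter. Compound 2 holds the lower of the two numbers, but its nearest neighbour, compound 1, sits within the scatter of it, so no order between the two is claimed and neither is called the more toxic.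

Compound 3 `Cc1cc(O)c(C2=NN(c3ccc(S(N)(=O)=O)cc3)C(/C=C/c3ccccc3)C2)cc1Cl` is not yet measured. The change from compound 2 is 2-phenylethenyl in place of 2-chlorophenyl on a saturated ring carbon. Among the compounds with values here, no measured step touches this group in this way. Within the data shown here, the only step available, the swap of hydroxy for chloro on an aromatic carbon at the same position, moved nothing beyond the scatter, so the position has so far tolerated one change without a shift in this assay. On that thin basis the expectation for compound 3 is no step beyond the scatter, a 1.1-fold lower number from compound 2 to compound 3 (0.04 log units; within the scatter), with a wide range because the entering group is of a different kind. Compound 3 is estimated at 20000 nM, between 7000 nM and 60000 nM.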

Compound 3, concentration lethal to 50% of the cells: > 100000 nM
Compound 3 gave a limit, no number; the forecaster's own chance of this, stated with the estimate: 10%; at least 5.0-fold (0.69 log units) between middle value and limit.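

The saturated ring carbon, which showed no shift beyond the scatter on the swap of hydroxy for chloro on its aromatic substituent, does respond in this assay when the ring attached there gives way to 2-phenylethenyl: the change gives an at least 4.5-fold higher number from compound 2 to compound 3 (0.65 log units; beyond the scatter), and the comparison with the 2-hydroxyphenyl analogue gives an at least 3.8-fold higher number from compound 1 to compound 3 (0.58 log units; beyond the scatter). The result for compound 3 is a limit of the assay and not a number: the limit of > 100000 nM in this assay, at which 1 of the 3 values shown sits. Both steps point to lower toxicity in this test, and they show that this position is not indifferent to the group it carries, even though 2-chlorophenyl and 2-phenylethenyl have the same hydrogen-bond donor and acceptor counts and no net charge.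

The compounds shown do not separate the double bond from the other differences in the entering group, and a saturated 2-phenylethyl group or an unsubstituted phenyl at this carbon would bear directly on that question. From the compounds shown here alone, how an amine such as dimethylaminomethyl or a carboxylic acid would read at this position also remains open.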